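Sulfonamide series: cyclohexyl for 4-methoxyphenyl on ring nitrogen

The source may hold more compounds than are shown below. What is called first, only, known or untested is meant among the compounds shown, and "the series" means these compounds.

Measured compounds in a functional assay on A-375 cells (Homo sapiens) for antiproliferative activity, read by MTT assay, with a stated time of 72 h; on this read-out higher numbers stand for weaker inhibition and lower numbers for stronger inhibition:
Compound 1 `COc1ncc(-c2ccc3c(c2)N(C2CCCCC2)C(=O)CO3)cc1NS(=O)(=O)c1ccc(F)cc1` gives only a limit, > 40000 nM.
Compound 2 `COc1ccc(N2C(=O)COc3ccc(-c4cnc(OC)c(NS(=O)(=O)c5ccc(F)cc5)c4)cc32)cc1` gives 18400 nM.
Compound 3 `COc1ccc(N2C(=O)COc3ccc(-c4cccc(NS(=O)(=O)c5ccc(F)cc5)c4)cc32)cc1` gives 38500 nM.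

Compound 2 and compound 1 share a core and differ in one place: cyclohexyl in place of 4-methoxyphenyl on an amide-type nitrogen in a ring. The step of an at least 2.1-fold higher number from compound 2 to compound 1 (0.33 log units; beyond the scatter) is open-ended because compound 1 sits at the limit of > 40000 nM in this assay, at which 1 of the 3 values shown sits. Compound 3 stands at the highest number of the two measured as numbers; its nearest neighbour is compound 2, and that gap lies beyond the scatter. How the core of compound 3 differs from the core of compound 2 is not broken down here.

Compound 4 `O=C1COc2ccc(-c3cccc(NS(=O)(=O)c4ccc(F)cc4)c3)cc2N1C1CCCCC1` is not yet measured. It relates to compound 3 as compound 1 relates to compound 2: cyclohexyl in place of 4-methoxyphenyl on an amide-type nitrogen in a ring. The two place descriptions agree word for word, so this is the same change, seen a second time in the series.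

Since compound 3 already gives 38500 nM, and the earlier instance of the change gave an at least 2.1-fold higher number from compound 2 to compound 1 (0.33 log units; beyond the scatter), the step of a 2.3-fold higher number from compound 3 to compound 4 (0.37 log units; beyond the scatter) is expected to go in the same direction, towards weaker inhibition of compound 4 in this assay. Compound 4 is estimated at 90000 nM in this assay, with a range from 40000 nM to 400000 nM.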

Compound 4, half-maximal inhibitory concentration: 23800 nM
Compound 4: the middle estimate sits 3.8-fold (0.58 log units) above what was measured; measured number below the stated range.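

In this assay, cyclohexyl in place of 4-methoxyphenyl on the amide-type nitrogen gives a 1.6-fold lower number from compound 3 to compound 4 (0.21 log units; within the scatter), so on the core of compound 3 the change produces no shift beyond the scatter. Set beside the earlier instance on the core of compound 2, the change does not carry over as a constant step in this series: the same change on two cores in this assay, an at least 2.1-fold higher number (0.33 log units; beyond the scatter) from compound 2 to compound 1 and a 1.6-fold lower number (0.21 log units; within the scatter) from compound 3 to compound 4, at least 3.5-fold (0.54 log units) apart, beyond the scatter of two such steps Compound 1 gives only a limit, so the earlier step has no fixed size, and the two pairs show that the outcome depends on the core without showing which feature of the core is responsible: the limit of > 40000 nM in this assay, at which 1 of the 4 values shown sits.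

Going by these compounds alone, with only two cores and two groups on this nitrogen, it remains open which of the two outcomes would be the more typical on a further core. On these data alone, it also remains open how a group of another kind at the same place, such as a chain ending in an amine or a carboxylic acid, would read in this assay, and whether it would behave differently on the core of compound 2 and the core of compound 3.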